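A few compounds are considered here, and "the series" means these few. Any claim that something is new, unique, unknown or untested is made for them only; others in the source may bear on it.

Working notes on the series. Compound 1 `COc1ccc(-c2nc3sc(Cc4ccccc4)nn3c2SC#N)cc1` is measured in a functional assay on cells (Cancer cell lines, Homo sapiens) for inhibition (on this read-out higher numbers stand for weaker inhibition of growth and lower numbers for stronger inhibition of growth), and gives 4100 nM there. Compound 2 `O=Cc1c(-c2ccc([N+](=O)[O-])cc2)nc2sc(Cc3ccccc3)nn12` gives 3100 nM in this assay, a number within the usual scatter of that of compound 1, so the two stand together. Compound 3 `N#CSc1c(-c2ccccc2)nc2sc(Cc3ccccc3)nn12` has not yet been measured. It differs from compound 1 by hydrogen in place of methoxy on an aromatic carbon. Among the compounds with values here, no measured pair shows this change, so the step from compound 1 is expected to stay within the scatter in this assay, with a 1.1-fold higher number from compound 1 to compound 3 (0.04 log units; within the scatter) as the estimate. Compound 3 is expected at 4500 nM, in the range 1500 nM to 13000 nM.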

Compound 3, concentration for 50% growth inhibition: 11200 nM
Compound 3: the middle estimate sits 2.5-fold (0.40 log units) below what was measured, and the stated range covers the measured number.
By their numbers in this assay, from the lowest: compounds 2 and 1 (each within the scatter of the next); then compound 3.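

Within the data shown here, replacing 4-methoxyphenyl with phenyl in this assay gives a 2.7-fold higher number from compound 1 to compound 3 (0.44 log units; beyond the scatter) and so marks the first step beyond the scatter. This position is therefore not indifferent to its substituent, and the methoxy compound gives the stronger inhibition of growth of the pair. No measured evidence bears on the reason for this step.

The compounds shown leave open whether methoxy is special at this place or whether a hydroxyl, an amine or a longer alkoxy chain would serve as well. They also leave open whether the step would hold with a group other than thiocyanate on the shared core.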